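The source may hold more compounds than are shown below. What is called first, only, known or untested is meant among the compounds shown, and "the series" means these compounds.

Values from a functional assay for inhibition (on this read-out higher numbers stand for weaker inhibition and lower numbers for stronger inhibition), follow for the two compounds measured so far:

Compound 1 (`CC(C)(C)c1cc(-c2cc(=O)c3ccc(OCC(=O)N4CCN(Cc5ccccc5)CC4)cc3o2)cc(C(C)(C)C)c1O`) gives (3000 nM)
Compound 2 (`CC(C)(C)c1cc(-c2cc(=O)c3ccc(OCCO)cc3o2)cc(C(C)(C)C)c1O`) gives (3000 nM)

Compound 2 stands level with compound 1, within the scatter, so neither can be ranked above the other. Compound 3 (`CC(C)(C)c1cc(-c2cc(=O)c3ccc(OCc4ccc(Cl)cc4)cc3o2)cc(C(C)(C)C)c1O`), not yet measured, keeps the shared core of compound 2. In it, 4-chlorophenyl stands in place of hydroxymethyl on a saturated chain carbon bound to an oxygen on an aromatic ring (4-chlorophenyl in place of hydroxymethyl on a saturated chain carbon bound to an oxygen on an aromatic ring), which also reads as 2-hydroxyethyl to 4-chlorobenzyl. For the measured compounds named here, no measured pair differs in one place only, so no direct precedent exists. Still, compound 1 (3000 nM) and compound 2 (3000 nM) carry very different groups on that oxygen and read level. In this assay no step beyond the scatter is therefore expected, with only a slight lean toward stronger inhibition in the estimated step (a 1.5-fold lower number from compound 2 to compound 3 (0.18 log units; within the scatter)). Compound 3 is estimated at 2000 nM with an expected range of 500 nM to 8000 nM (an estimate, not a measurement).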

Compound 3, half-maximal inhibitory concentration: 7000 nM
For compound 3 the middle estimate is 3.5-fold (0.54 log units) below the measured one, within the range that was stated.
By their numbers in this assay, from the lowest: compounds 1 and 2 (each within the scatter of the next); then compound 3.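

In this assay, replacing 2-hydroxyethyl with 4-chlorobenzyl on the oxygen gives a 2.3-fold higher number from compound 2 to compound 3 (0.37 log units; beyond the scatter), a modest weakening of inhibition. This shows that the read-out does respond to a change at this position, although the loss is small for a swap that removes hydroxymethyl, with its hydrogen-bond donor and acceptor, and brings in a six-membered aromatic ring bearing chlorine. Nothing available explains why the number rises.

On these data alone, it remains open whether the shift follows from losing the hydroxymethyl, gaining the aromatic ring or adding the chlorine, and an unsubstituted benzyl group on the same oxygen would help to separate these. As far as these compounds go, how a carboxylic acid or a simple amine on a short chain at this oxygen would read also remains open.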